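Chloro Added to the Phenyl Ring of Compound 2

This account rests on a few compounds, and the source may have more. Where it says the series, first, only, none or still open, it means among the compounds named here.

For the measured compounds named here, in a functional assay on HT-29 cells (Homo sapiens) for antiproliferative activity, read by MTT assay, with a stated time of 72 h (on this read-out lower numbers stand for stronger inhibition and higher numbers for weaker inhibition), compound 2 `CCCNC(=O)c1cc(Oc2ccc(NC(=O)c3cc4cccnc4n(-c4ccccc4)c3=O)cc2)ccn1` gives 98 nM, the lowest of the two numbers known; its nearest neighbour, compound 1 `CCNC(=O)c1cc(Oc2ccc(NC(=O)c3cc4cccnc4n(-c4ccccc4)c3=O)cc2)ccn1`, gives 220 nM. Going by the values given here, the one measured step, a 2.2-fold lower number from compound 1 to compound 2 (0.35 log units; beyond the scatter), concerns the chain on the opposite side of the molecule. Compound 3 `CCCNC(=O)c1cc(Oc2ccc(NC(=O)c3cc4cccnc4n(-c4ccc(Cl)cc4)c3=O)cc2)ccn1` differs from compound 2 by chloro in place of hydrogen on an aromatic carbon, phenyl becoming 4-chlorophenyl. Among the compounds with values here, no measured step touches this ring, so the expected change is a 1.2-fold lower number from compound 2 to compound 3 (0.06 log units; within the scatter), nothing beyond the scatter. For compound 3 the estimate in this assay is 85 nM, between 30 nM and 250 nM.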

Compound 3, half-maximal inhibitory concentration: 390 nM
Compound 3: middle estimate off by 4.6-fold (0.66 log units), on the low side; the whole stated range lies below it.
By their numbers in this assay, from the lowest: compound 2; then compounds 1 and 3 (each within the scatter of the next).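

This ring, untouched by the earlier step, turns out not to be a silent spot: in this assay, phenyl becoming 4-chlorophenyl gives a 4.0-fold higher number from compound 2 to compound 3 (0.60 log units; beyond the scatter), so one added chlorine, para to a large group, weakens inhibition beyond the scatter. A single heavy atom on this aromatic carbon is therefore enough to shift the read-out. No measurement available here gives a reason for this loss.

From the compounds shown here alone, whether it is specific to chloro remains open, since fluoro or methoxy at this carbon would be needed to tell. Chloro on another carbon of this ring is equally open.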